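Selenium nucleosides: hydroxy in place of amino on the base

A few compounds are considered here, and "the series" means these few. Any claim that something is new, unique, unknown or untested is made for them only; others in the source may bear on it.

Compound 1 `O=c1ccn([C@H]2C[Se][C@@H](CO)O2)c(=O)[nH]1` and compound 2 `Nc1ncnc2c1ncn2[C@H]1C[Se][C@@H](CO)O1` share the same core and differ only in the base. In a functional assay on PBM cells (Homo sapiens) for cytotoxicity (on this read-out lower numbers stand for stronger inhibition and higher numbers for weaker inhibition), compound 1 gives > 100000 nM, which is a limit of the assay rather than a number. In this assay compound 2 also gives > 100000 nM, again a limit. Compound 2 thus stands at the limit of > 100000 nM in this assay, at which 2 of the 2 values shown sit. Compound 3 `OC[C@H]1O[C@@H](n2cnc3c(O)ncnc32)C[Se]1` carries hydroxy in place of amino on an aromatic carbon. Among the measured compounds shown here, no measured step shows how such a change plays out here, so compound 3 is expected to stay at the limit, its expected step that the limit leaves unreadable from compound 2 to compound 3 being none beyond the scatter. Compound 3 is therefore estimated at 150000 nM, between 60000 nM and 400000 nM.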

Compound 3, half-maximal inhibitory concentration: > 100000 nM
Compound 3 was reported as a limit; the forecaster's own chance of this, stated with the estimate: 85%; the middle value does not contradict the limit.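

Compound 2 and compound 3 both read as limits in this assay, so no step between them can be read: the limit of > 100000 nM in this assay, at which 3 of the 3 values shown sit.

The compounds shown leave open what hydroxy in place of amino does to a compound that gives a number rather than a limit in this assay.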